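Moving a Methyl Around a Phenyl Ring

The source may hold more compounds than are shown below. What is called first, only, known or untested is meant among the compounds shown, and "the series" means these compounds.

Compound 1 `Cc1ccc(-c2c(C)nn(-c3nc(-c4ccc(Cl)c(Cl)c4)c(SC(C)C)s3)c2C(=O)O)cc1` belongs to a small set of three compounds tested in a functional assay on BJAB cells (Homo sapiens) for antiproliferative activity, with a stated time of 4 days; a lower number here means that less compound is needed, a higher number that more compound is needed for the effect. In this assay compound 1 gives 3800 nM, the lowest of the three numbers. Compound 3 `Cc1c(-c2cc(Cl)cc(Cl)c2)c(C(=O)O)nn1-c1nc(-c2cc(Cl)ccc2F)c(SC(C)C)s1` gives 4800 nM, which lies within the scatter of compound 1, so the two cannot be ranked against each other. Compound 2 `CCSc1sc(-n2nc(C)c(Cc3ccccc3[N+](=O)[O-])c2C(=O)O)nc1-c1ccc(Cl)c(Cl)c1` gives 59000 nM, a number beyond the scatter above compound 1; it is the only one of the three that carries a nitro group.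

Compound 4 `Cc1ccccc1-c1c(C)nn(-c2nc(-c3ccc(Cl)c(Cl)c3)c(SC(C)C)s2)c1C(=O)O` differs from compound 1 in one place: 2-methylphenyl in place of 4-methylphenyl on an aromatic carbon. Among the compounds with values here, the set holds no pair of measured compounds that differ only in this way, so the size and direction of this step cannot be read from anything already measured. With the two compounds sharing every atom and differing only in where the methyl sits on the phenyl ring, the expected step from compound 1 to compound 4 is a 1.3-fold higher number from compound 1 to compound 4 (0.12 log units; within the scatter), a small one with a slight lean toward a higher number. In this assay compound 4 is therefore expected to give 5000 nM, within a range from 1500 nM to 20000 nM.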

Compound 4, half-maximal effective concentration: 5500 nM
Estimate against measurement, compound 4: 1.1-fold (0.04 log units) below; low and high end bracket the measured number.
By their numbers in this assay, from the lowest: compounds 1, 3 and 4 (each within the scatter of the next); then compound 2.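

Within the data shown here, exchanging 4-methylphenyl for 2-methylphenyl on an aromatic carbon of the five-membered aromatic ring gives the first step that can be read at this position, with a 1.4-fold higher number from compound 1 to compound 4 (0.16 log units; within the scatter) in this assay as its size. The earlier compounds shown here differ from one another in more than one place, so they could not show how the number responds to a single change here. For this one pair, moving the methyl around the phenyl ring, with the same atoms and with no hydrogen-bond donors or acceptors on either group, leaves compound 1 and compound 4 unranked, and nothing shown indicates why the step has this size.

One pair at one position says nothing about whether the same exchange would give a similar step with a different thioether or a different aryl group elsewhere on the core. The compounds shown also leave open how an unsubstituted phenyl, a methoxyphenyl or a trifluoromethylphenyl would compare with compound 1 at this position in this assay when placed on the same aromatic carbon.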